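The source may hold more compounds than are shown below. What is called first, only, known or untested is meant among the compounds shown, and "the series" means these compounds.

Of the compounds shown here, two built on one shared core have been tested in a functional assay on RPMI-8226 cells (Homo sapiens) for inhibition, read by sulforhodamine B assay, with a stated time of 48 h; a higher number here means a weaker inhibitor of growth, a lower number a stronger inhibitor of growth. Compound 1 `COc1ccc(-c2cc(-c3cccn3C)c(C#N)c(=O)[nH]2)cc1OC` reaches only the limit of the measurement, giving > 100000 nM. Compound 2 `Cn1cccc1-c1cc(-c2cccs2)[nH]c(=O)c1C#N` likewise stops at the limit, giving > 100000 nM. Compound 2 thus stands nowhere on a scale of real numbers: its result, like the one other result, is a limit rather than a value, as the limit of > 100000 nM in this assay, at which 2 of the 2 values shown sit, makes plain. Compound 3 `Cn1cccc1-c1cc(-c2ccccc2)[nH]c(=O)c1C#N` is the next member of the series; it differs from compound 2 by phenyl in place of thiophen-2-yl on an aromatic carbon. Among the compounds with values here, no measured step between compounds exists here, so the expectation for compound 3 rests only on the two limits. Both known results sit at the limit, which is what the limit of > 100000 nM in this assay, at which 2 of the 2 values shown sit, records, and no direction can be read from them; the expected step of a number no higher from compound 2 to compound 3 (the limit leaves the size open) is none beyond the scatter. The estimate for compound 3 in this assay is accordingly 100000 nM, with a likely range from 30000 nM to 300000 nM, and the most probable outcome is that the measurement again reports only a limit.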

Compound 3, concentration for 50% growth inhibition: > 100000 nM
Compound 3 gave a limit, no number (the forecaster's own chance of this, stated with the estimate: 85%); the middle value sits exactly at the limit.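

In this assay, within the data shown here, compound 3 gives only a limit, as compound 2 does, so no step between compound 2 and compound 3 can be read. The compounds shown leave open how strongly any of them inhibits growth, and whether phenyl or thiophen-2-yl on the shared core makes any difference to that.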